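This account rests on a few compounds, and the source may have more. Where it says the series, first, only, none or still open, it means among the compounds named here.

Working notes on the amide series around compound 1 `CCn1c(C(=O)NCCCN(C)C)ccc1C(CC)(CC)c1ccc(OCCC(O)(CC)CC)c(C)c1`. In a functional assay on PC-3 cells (Homo sapiens) for antiproliferative activity, read by MTT assay, with a stated time of 48 h (on this read-out higher numbers stand for weaker inhibition and lower numbers for stronger inhibition), compound 1 gives 2150 nM, the lowest of the two numbers in hand. Replacing the amide substituent has so far only raised the number: compound 2 `CCn1c(C(=O)NCC#N)ccc1C(CC)(CC)c1ccc(OCCC(O)(CC)CC)c(C)c1` gives 17800 nM, a step of an 8.3-fold higher number from compound 1 to compound 2 (0.92 log units; beyond the scatter). Compound 3 `CCn1c(C(=O)N(CCC#N)CCC#N)ccc1C(CC)(CC)c1ccc(OCCC(O)(CC)CC)c(C)c1` reaches only the limit of the assay, > 50000 nM. That limit, (the limit of > 50000 nM in this assay, at which 1 of the 3 values shown sits), defines the steps of an at least 23-fold higher number from compound 1 to compound 3 (1.36 log units; beyond the scatter) and an at least 2.8-fold higher number from compound 2 to compound 3 (0.44 log units; beyond the scatter).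

Compound 4 `CCC(C)C(NC(=O)c1ccc(C(CC)(CC)c2ccc(OCCC(O)(CC)CC)c(C)c2)n1CC)C(=O)O` differs from compound 1 at the same amide-type nitrogen: 1-carboxy-2-methylbutyl in place of 3-(dimethylamino)propyl on an amide-type nitrogen. The two measured steps at this position, an 8.3-fold higher number from compound 1 to compound 2 (0.92 log units; beyond the scatter) and an at least 23-fold higher number from compound 1 to compound 3 (1.36 log units; beyond the scatter), both bear on it and both went beyond the scatter toward weaker inhibition, the larger one ending at the limit. A higher number than compound 1 is therefore expected for compound 4, most likely of the size seen for compound 2 or beyond, with a real chance that only a limit is returned. Estimated step: a 7.0-fold higher number from compound 1 to compound 4 (0.84 log units; beyond the scatter). Compound 4 is estimated at 15000 nM, within 4000 nM to 50000 nM.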

Compound 4, half-maximal inhibitory concentration: 13800 nM
Compound 4: middle estimate off by 1.1-fold (0.04 log units), on the high side; the range from low to high includes it.
By their numbers in this assay, from the lowest: compound 1; then compounds 4 and 2 (each within the scatter of the next). At a limit, above all of these: compound 3.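

Exchanging 3-(dimethylamino)propyl for 1-carboxy-2-methylbutyl on the amide-type nitrogen gives (a 6.4-fold higher number from compound 1 to compound 4 (0.81 log units; beyond the scatter)), so a substituent carrying a carboxylic acid also leaves the number above that of compound 1. Against cyanomethyl, the same group gives (a 1.3-fold lower number from compound 2 to compound 4 (0.11 log units; within the scatter)), so two substituents with different end groups cannot be told apart on this read-out. The comparison with compound 3 (an at least 3.6-fold lower number from compound 3 to compound 4 (0.55 log units; beyond the scatter)) gives only a bound, since the value of compound 3 is a limit: (the limit of > 50000 nM in this assay, at which 1 of the 4 values shown sits).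

Open, from the compounds shown here alone, is whether a methyl ester in place of the carboxylic acid of compound 4 would hold its number, and whether a primary amine or a longer chain ending in dimethylamino would fall below compound 1. The compounds shown also do not separate the carboxylic acid from the branched chain within 1-carboxy-2-methylbutyl.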